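Opening the Ring Into an Acid-Bearing Chain

This account rests on a few compounds, and the source may have more. Where it says the series, first, only, none or still open, it means among the compounds named here.

In an assay on microsomes from liver for inhibition of sterol O-acyltransferase 1 (Rattus norvegicus) (on this read-out higher numbers stand for weaker inhibition and lower numbers for stronger inhibition), compound 1 `CCCCCCn1nc(-c2ccccc2)c(-c2ccccc2)cc1=O` gives 57000 nM. Compound 2 `O=c1cc(-c2ccccc2)c(-c2ccccc2)nn1C1CCCC1` gives 119000 nM in this assay. For compound 3 `O=c1cc(-c2ccccc2)c(-c2ccccc2)nn1C1CCCCC1` this assay reports only a limit, > 300000 nM, which places it at the weak end of the three. The steps of an at least 5.2-fold higher number from compound 1 to compound 3 (0.72 log units; beyond the scatter) and an at least 2.5-fold higher number from compound 2 to compound 3 (0.40 log units; beyond the scatter) show that the ring-shaped groups gave weaker inhibition than the open hexyl chain. Compound 4 `O=C(O)CCCCCCn1nc(-c2ccccc2)c(-c2ccccc2)cc1=O` differs from compound 3 by 6-carboxyhexyl in place of cyclohexyl on an aromatic nitrogen. Within the data shown here, because this change reverses the direction of an at least 5.2-fold higher number from compound 1 to compound 3 (0.72 log units; beyond the scatter), compound 4 is expected to show a decrease an at least 3.0-fold lower number from compound 3 to compound 4 (0.47 log units; beyond the scatter), though the carboxylic acid has no counterpart among the measured compounds. Compound 4 is estimated at 100000 nM, within 30000 nM to 300000 nM.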

Compound 4, half-maximal inhibitory concentration: > 300000 nM
Compound 4: no number, only a limit; the forecaster's own chance of this, stated with the estimate: 30%; at least 3.0-fold (0.47 log units) between middle value and limit.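

Placing a carboxy group at the end of the hexyl chain gives an at least 5.2-fold higher number from compound 1 to compound 4 (0.72 log units; beyond the scatter), so an open chain at this nitrogen does not by itself keep the inhibition seen with hexyl. The 6-carboxyhexyl group also falls behind cyclopentyl, with an at least 2.5-fold higher number from compound 2 to compound 4 (0.40 log units; beyond the scatter). The step between compound 3 and compound 4 cannot be read because each reports a limit rather than a number: the limit of > 300000 nM in this assay, at which 2 of the 4 values shown sit.

Still open, as far as these compounds go, is whether an amine or a methyl ester at the end of the chain would fare better than the carboxylic acid. How a longer plain chain would compare with hexyl is also unknown.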